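The source may hold more compounds than are shown below. What is called first, only, known or untested is meant among the compounds shown, and "the series" means these compounds.

Series notes. Three compounds sharing one core have been run so far: compound 1 `CC#C[C@H](CC(=O)O)c1ccc(OC[C@H]2COc3ccc(Cl)cc3O2)cc1`, compound 2 `CC#C[C@@H](CC(=O)O)c1ccc(OC[C@H]2COc3c(Cl)cccc3O2)cc1` and compound 3 `CC#C[C@@H](CC(=O)O)c1ccc(OC[C@H]2COc3ccc(F)cc3O2)cc1`, all in a functional assay on HEK293 cells for agonist activity at Free fatty acid receptor 1 (Homo sapiens), read by fluorescence and calcium flux, with a stated time of 10 min; a higher number here means a larger maximal response, a lower number a smaller maximal response. In this assay compound 1 gives 47%, compound 2 gives 81% and compound 3 gives 86%. The number of compound 3 is the highest of the three, but compound 2 lies within the usual scatter of it, so those two cannot be told apart; compound 1 sits well beyond the scatter below both.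

Compound 4 `CC#C[C@@H](CC(=O)O)c1ccc(OC[C@H]2COc3ccc(C(C)=O)cc3O2)cc1` has not yet been measured. It differs from compound 3 in one place: acetyl in place of fluoro on an aromatic carbon. For the measured compounds named here, no measured pair carries this change, so there is no step to lean on. Going by the values given here, what the numbers do show is that compound 2 and compound 3 both reach a high maximal response while compound 1 falls off, with no single-point step among them. The step of a number 6 percentage points lower from compound 3 to compound 4 (within the scatter) is expected to be small, if anything a slight drop, and not clearly beyond the scatter. The estimate for compound 4 in this assay is 80%, with a range from 60% to 100%.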

Compound 4, largest response reached (Emax), in percent of the reference or control that the assay uses: 51%
Compound 4: the middle estimate sits 29 percentage points above what was measured; the whole stated range lies above it.
By their numbers in this assay, from the lowest: compounds 1 and 4 (each within the scatter of the next); then compounds 2 and 3 (each within the scatter of the next).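

In this assay the series now has its first step between compounds that differ in one place: with acetyl in place of fluoro on an aromatic carbon, meta to a fused ring and para to a fused ring, the record shows a number 35 percentage points lower from compound 3 to compound 4 (beyond the scatter) for this change. For the compounds shown here, the earlier compounds offered no such pair, so this is the first direct sign that the maximal response depends on the group at this position and that the position does not accept every replacement of fluoro equally. No measurement shown here accounts for the fall in maximal response.

A single pair cannot show whether the fall belongs to acetyl itself or to the swap of one heavy atom for three, or whether the carbonyl oxygen matters, and a methoxy group, a nitrile or an amine at the same carbon would begin to separate these readings. Going by these compounds, it also remains open whether the same change would give a step of similar size on the opposite configuration of the carbon bearing the acid chain.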